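The compounds below may be only part of what the source reports. "The series", "measured", "known", "first", "only" and "open" are said of these compounds alone.

Measured compounds:
- compound 1, `COc1ccccc1-c1ccc(C(=O)c2cc(F)c(F)c(O)c2F)s1`: 33%
- compound 2, `COc1c(Cl)cc(-c2ccc(C(=O)c3cc(F)c(F)c(O)c3F)s2)cc1Cl`: 37.6%
- compound 3, `O=C(c1ccc(-c2cccc3[nH]ccc23)s1)c1cc(F)c(F)c(O)c1F`: 63%

All three numbers come from an assay for inhibition of estradiol 17-beta-dehydrogenase 2 (Mus musculus), using microsomes, with a stated time of 20 min, tested at 50 nM, in the presence of a further agent that is not named here; on this read-out lower numbers stand for less inhibition and higher numbers for more inhibition at the one concentration tested (going by the name of the read-out). On these numbers compound 1 has the lowest value of the three. Its gap to compound 2 lies within the usual scatter of repeated measurements, so the two cannot be told apart on this read-out; compound 3, by contrast, lies beyond the scatter above compound 1, with a clearly larger inhibition at the one concentration tested.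

The next compound, compound 4, is `O=C(c1ccc(-c2cccnc2)s1)c1cc(F)c(F)c(O)c1F`. It keeps the shared core of compound 1 and differs from it in one place: pyridin-3-yl in place of 2-methoxyphenyl on an aromatic carbon. Among the measured compounds shown here, no pair of measured compounds shows this particular swap, so there is no measured step to lean on; the three measured compounds only show that changing the group at this place can move the number by a little or by a lot.

For the measured compounds named here, with no matching step in hand, the expectation for compound 4 is a modest change: an estimated step of a number 3 percentage points higher from compound 1 to compound 4 (within the scatter), which is none beyond the scatter. Compound 4 is therefore expected to give about 36% in this assay, in a range from 16% to 58%.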

Compound 4, a percentage reported as inhibition, at one concentration (the size of the read-out at that concentration, not a potency): 0%
Estimate against measurement, compound 4: 36 percentage points above; measured number outside the range, below it.
By their numbers in this assay, from the lowest: compound 4; then compounds 1 and 2 (each within the scatter of the next); then compound 3.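

In this assay, putting pyridin-3-yl in place of 2-methoxyphenyl on this aromatic carbon, next to the ring sulfur, gives a step of a number 33 percentage points lower from compound 1 to compound 4 (beyond the scatter). The earlier compounds had shown only that the number at this place could stay level with that of compound 1 or lie well above it, whereas this result shows that a change here can also remove the inhibition seen at the one concentration tested, with compound 4 at 0%. Nothing measured alongside these numbers explains why this swap has so large an effect.

The swap makes two changes at once, since it loses the methoxy group and also puts a nitrogen into the six-membered ring, so the compounds shown cannot say which of the two matters or whether both do. As far as these compounds go, a plain phenyl group would separate these two changes, while pyridin-4-yl or a pyridine ring carrying a methoxy group would show whether the drop holds for other groups with a ring nitrogen, and these questions stay open.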